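Inverting the Stereocentre of Compound 2

A few compounds are considered here, and "the series" means these few. Any claim that something is new, unique, unknown or untested is made for them only; others in the source may bear on it.

Measured so far:
Compound 1, `C[C@@H](NC(=O)c1[nH]cnc1C(=O)Nc1ccc(Cl)c(Cl)c1)c1ccccc1`: 8800 nM
Compound 2, `C[C@@H](c1ccccc1)N(C)C(=O)c1[nH]cnc1C(=O)Nc1ccc(Cl)c(Cl)c1`: 75500 nM

Both compounds were tested in a functional assay on HL-60 cells (Homo sapiens), with a stated time of 2 days; on this read-out higher numbers stand for weaker inhibition and lower numbers for stronger inhibition. Compound 1 gives 8800 nM, while compound 2 gives 75500 nM. Compound 2 therefore stands highest of the two numbers, showing the weaker inhibition, and the gap to compound 1 lies beyond the usual scatter of the measurement.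

Compound 3, `C[C@H](c1ccccc1)N(C)C(=O)c1[nH]cnc1C(=O)Nc1ccc(Cl)c(Cl)c1`, is the mirror image of compound 2 at its single stereocentre: the two compounds have the same atoms and bonds and differ only in configuration as drawn: 1 of 1 stereo elements differ; a stereocentre at a saturated chain carbon is drawn S in compound 2 and R in compound 3. Going by the values given here, no measured pair in this set differs in configuration alone, so there is no direct guide to how large such a change is here. Mirror-image pairs often differ markedly, but the direction is unknown in this case.

Compound 3 is expected to give about 45000 nM, with a likely range from 8000 nM to 200000 nM. The expected step, a 1.7-fold lower number from compound 2 to compound 3 (0.22 log units; within the scatter), is small against that wide range.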

Compound 3, half-maximal inhibitory concentration: 89400 nM
Compound 3: the middle estimate sits 2.0-fold (0.30 log units) below what was measured, within the range that was stated.
By their numbers in this assay, from the lowest: compound 1; then compounds 2 and 3 (each within the scatter of the next).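

In this assay, swapping the configuration at the saturated chain carbon gives a 1.2-fold higher number from compound 2 to compound 3 (0.07 log units; within the scatter), so with a methyl on the amide-type nitrogen, this assay does not tell the two mirror images apart. Methyl in place of hydrogen on that nitrogen, with nothing else altered, gives a 10-fold higher number from compound 1 to compound 3 (1.01 log units; beyond the scatter), which makes this the first clean single-change step at this position and a large one. The reading of the mirror-image pair as a test of configuration alone rests on one structural fact: the fact that compounds 2 and 3 differ only in the configuration as drawn

The compounds shown leave open whether configuration would count for as little with the amide hydrogen in place. They also leave open whether an ethyl group, or a longer chain ending in an amine, on that nitrogen would behave as methyl does.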